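Azido to diisopropylamino on the shared core

The source may report more compounds than this note shows. Statements on the series, on what has been measured and on what is new or still open speak of the compounds shown alone.

In a functional assay on L1210 cells (Mus musculus) for inhibition, with a stated time of 72 h (on this read-out lower numbers stand for stronger inhibition and higher numbers for weaker inhibition), compound 1 `[N-]=[N+]=NCc1ncnc2c1ncn2[C@@H]1O[C@H](CO)[C@@H](O)[C@H]1O` gives 1590 nM, the lowest number among the measured values. Compound 3 `OC[C@H]1O[C@@H](n2cnc3c(CN4CCCCC4)ncnc32)[C@H](O)[C@@H]1O` gives 12200 nM, the nearest measured value. Compound 2 `CSCc1ncnc2c1ncn2[C@@H]1O[C@H](CO)[C@@H](O)[C@H]1O` gives > 30000 nM, which is a limit of the assay and not a number.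

The step under study leads to compound 4 `CC(C)N(Cc1ncnc2c1ncn2[C@@H]1O[C@H](CO)[C@@H](O)[C@H]1O)C(C)C`: diisopropylamino in place of azido on a saturated chain carbon bound to an aromatic carbon. In words, diisopropylamino stands in place of azido on a saturated chain carbon bound to an aromatic carbon.

Among the measured compounds shown here, two measured steps bear on this change. The closer guide is a 7.7-fold higher number from compound 1 to compound 3 (0.88 log units; beyond the scatter), where piperidin-1-yl replaces azido; this step is modest. The other is an at least 18-fold higher number from compound 1 to compound 2 (1.27 log units; beyond the scatter), where methylsulfanyl replaces azido; this step is large. Both raise the number, so a modest to large rise is expected in this assay for compound 4. The expected change is an 8.8-fold higher number from compound 1 to compound 4 (0.94 log units; beyond the scatter). Compound 4 is estimated at 14000 nM, with an expected range of 5000 nM to 30000 nM.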

Compound 4, half-maximal inhibitory concentration: 17000 nM
Compound 4: the middle estimate sits 1.2-fold (0.08 log units) below what was measured; measured number inside the range.
By their numbers in this assay, from the lowest: compound 1; then compounds 3 and 4 (each within the scatter of the next). At a limit, above all of these: compound 2.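

In this assay, a second amine on this saturated chain carbon bound to an aromatic carbon also falls well short of azido, with an 11-fold higher number from compound 1 to compound 4 (1.03 log units; beyond the scatter). Diisopropylamino in place of piperidin-1-yl gives a 1.4-fold higher number from compound 3 to compound 4 (0.14 log units; within the scatter), so these two groups cannot be told apart in this pair. Compound 2 stands at a limit of the assay and not at a number: the limit of > 30000 nM in this assay, at which 1 of the 4 values shown sits.

Diisopropylamino in place of methylsulfanyl gives an at least 1.7-fold lower number from compound 2 to compound 4 (0.24 log units; that floor lies within the scatter), and a floor of that size does not separate these two groups.

Going by these compounds, whether a primary amine, a hydroxyl or dimethylamino on this carbon would stay closer to compound 1 remains open. Also open, on these data alone, is whether any replacement of azido at this place can give a lower number than compound 1.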